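The source may report more compounds than this note shows. Statements on the series, on what has been measured and on what is new or still open speak of the compounds shown alone.

Series notes. Compound 1 `C=C(Cl)C(=O)Nc1cc(Nc2nccc(-c3cn(C)c4ccccc34)n2)c(OC)cc1N(C)CCN(C)C` and compound 2 `C/C=C\C(=O)Nc1cc(Nc2nccc(-c3cn(C)c4ccccc34)n2)c(OC)cc1N(C)CCN(C)C` share one core and differ only in the acyl group on the amide. Among the measured compounds shown here, in a functional assay on NCI-H1975 cells (Homo sapiens) for antiproliferative activity, read by MTT assay, with a stated time of 72 h (a higher number here means a weaker inhibitor, a lower number a stronger inhibitor), compound 1 gives 1290 nM, the lowest of the two numbers available so far; compound 2 gives 4540 nM. For the measured compounds named here, the one step measured, a 3.5-fold higher number from compound 1 to compound 2 (0.55 log units; beyond the scatter), concerns the acyl group alone.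

Compound 3 `C=C(Cl)C(=O)Nc1cc(Nc2ncc(C#N)c(-c3cn(C)c4ccccc34)n2)c(OC)cc1N(C)CCN(C)C` keeps the acyl group of compound 1 and alters the core instead: cyano in place of hydrogen on an aromatic carbon. Going by the values given here, no measured step touches that part of the structure, so the comparison between compound 1 and compound 2 gives no direct guide, and nothing in the two numbers at hand says in which direction this change should move the readout, or whether it moves it at all. The expectation therefore rests on compound 1 as anchor, set at 1290 nM, with a wide range placed around it. For compound 3 the estimate is 900 nM, with a range from 250 nM to 3500 nM. The expected step of a 1.4-fold lower number from compound 1 to compound 3 (0.16 log units; within the scatter) is taken as none beyond the scatter, for want of any bearing comparison.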

Compound 3, half-maximal inhibitory concentration: 1620 nM
The estimate for compound 3 lay 1.8-fold (0.26 log units) below the measured number, within the range that was stated.
By their numbers in this assay, from the lowest: compounds 1 and 3 (each within the scatter of the next); then compound 2.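

At the aromatic carbon ortho to the 1-methyl-1H-indol-3-yl group and two atoms from the ring nitrogen, cyano in place of hydrogen gives a 1.3-fold higher number from compound 1 to compound 3 (0.10 log units; within the scatter) in this assay, so with the 1-chloroethenyl acyl group in place, this core change leaves the readout within the scatter. Among the compounds shown here, in this single pair the position carries cyano without a step beyond the scatter, whereas the acyl change, a 3.5-fold higher number from compound 1 to compound 2 (0.55 log units; beyond the scatter), remains the only step of that kind among the three compounds. Nothing at hand bears on why the cyano step stays this small.

On these data alone, whether the same carbon tolerates other groups, such as an amine, a carboxylic acid or a longer alkyl chain, remains open, since one substituent defines no trend for the position. Also open, as far as these compounds go, is whether cyano would behave the same way alongside the prop-1-en-1-yl acyl group of compound 2, or whether the result holds only with the 1-chloroethenyl acyl group shared by compound 1 and compound 3.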